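The compounds below may be only part of what the source reports. "The series", "measured", "known", "first", "only" and "open" are said of these compounds alone.

Measured so far in an assay on CHO cells with 5-hydroxytryptamine receptor 1D (Homo sapiens) as the target; a higher number here means a weaker inhibitor, a lower number a stronger inhibitor:
- compound 1 `CN(CC1CC1)CC1(O)CCN(CCCc2c[nH]c3ccc(-n4cnnc4)cc23)CC1` — 1.35 nM
- compound 2 `CN(CC(C)(C)C)CC1(O)CCN(CCCc2c[nH]c3ccc(-n4cnnc4)cc23)CC1` — 1.8 nM

Compound 2 sits with the highest of the two numbers in this assay, and its nearest neighbour compound 1 lies within the scatter of it. Compound 3 `Cc1ccccc1CNCC1(O)CCN(CCCc2c[nH]c3ccc(-n4cnnc4)cc23)CC1` differs from compound 2 by (2-methylbenzyl)amino in place of methyl(neopentyl)amino on a saturated chain carbon bound to a saturated ring carbon. Within the data shown here, the only measured step, a 1.3-fold higher number from compound 1 to compound 2 (0.12 log units; within the scatter), shows that exchanging the branched group on the amine leaves the number essentially unchanged, yet the change to compound 3 also removes the methyl on the amine and brings in an aromatic ring, for which no measured step exists. A small shift is expected, a 1.7-fold higher number from compound 2 to compound 3 (0.22 log units; within the scatter). Compound 3 is estimated at 3 nM (range 1 nM to 10 nM).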

Compound 3, half-maximal inhibitory concentration: 4 nM
Estimate against measurement, compound 3: 1.3-fold (0.12 log units) below; the range from low to high includes it.
By their numbers in this assay, from the lowest: compounds 1 and 2 (each within the scatter of the next); then compound 3.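

In this assay, a change at the saturated chain carbon bound to a saturated ring carbon now gives steps beyond the scatter: (2-methylbenzyl)amino gives a 2.2-fold higher number from compound 2 to compound 3 (0.35 log units; beyond the scatter) and a 3.0-fold higher number from compound 1 to compound 3 (0.47 log units; beyond the scatter). Both steps are modest, so this position accepts an aromatic ring and an amine hydrogen with only a limited rise in the number. No measured property bears on these steps.

Compound 3 brings in the ring and the amine hydrogen together, and the two contributions remain unseparated. Open: how methyl(2-methylbenzyl)amino or plain benzylamino would read at this position.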